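Amide groups on the carbonyl: compound 3 to compound 4

A few compounds are considered here, and "the series" means these few. Any claim that something is new, unique, unknown or untested is made for them only; others in the source may bear on it.

Measured in a functional assay on MCF7 cells (Homo sapiens) for antiproliferative activity, read by MTT assay, with a stated time of 48 h; a higher number here means a weaker inhibitor, a lower number a stronger inhibitor:
- compound 1 `CCn1c(C(=O)Nc2cccc(C(F)(F)F)c2)ccc1C(CC)(CC)c1ccc(OCCC(O)(CC)CC)c(C)c1`: > 50000 nM (a limit, not a number)
- compound 2 `CCOc1ccc(NC(=O)c2ccc(C(CC)(CC)c3ccc(OCCC(O)(CC)CC)c(C)c3)n2CC)cc1`: > 50000 nM (a limit, not a number)
- compound 3 `CCn1c(C(=O)N(C)CC(=O)O)ccc1C(CC)(CC)c1ccc(OCCC(O)(CC)CC)c(C)c1`: 79 nM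

Among the measured compounds shown here, compound 3 holds the only true number here, and the other two values stand at the limit of > 50000 nM in this assay, at which 2 of the 3 values shown sit. The measured steps to it are large: an at least 630-fold lower number from compound 1 to compound 3 (2.80 log units; beyond the scatter) and an at least 630-fold lower number from compound 2 to compound 3 (2.80 log units; beyond the scatter). Beside these stands a step that the two limits leave unreadable from compound 1 to compound 2.

Compound 4 `CCC(C)C(CO)NC(=O)c1ccc(C(CC)(CC)c2ccc(OCCC(O)(CC)CC)c(C)c2)n1CC` has not yet been measured. Its change from compound 3 falls at the same site, on a carbonyl carbon: (1-(hydroxymethyl)-2-methylbutyl)amino in place of (carboxymethyl)(methyl)amino on a carbonyl carbon. The group that leaves and the group that enters both have no ring, while the (3-(trifluoromethyl)phenyl)amino of compound 1 and the (4-ethoxyphenyl)amino of compound 2 do.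

Those two steps are the only ones that bear on the change, and neither removes the (carboxymethyl)(methyl)amino group in favour of another group without a ring. Compound 4 is therefore expected to sit closer to compound 3 than to the limit, though with a higher number in this assay. The expected size is a 5.1-fold higher number from compound 3 to compound 4 (0.70 log units; beyond the scatter), an estimate with wide uncertainty. The estimate for compound 4 is 400 nM, with an expected range from 40 nM to 10000 nM.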

Compound 4, half-maximal inhibitory concentration: 29100 nM
The estimate for compound 4 lay 73-fold (1.86 log units) below the measured number; measured number outside the range, above it.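

In this assay, the change on the carbonyl carbon gives a 370-fold higher number from compound 3 to compound 4 (2.57 log units; beyond the scatter), so a group without a ring does not by itself keep the number near that of compound 3. Among the compounds shown here, the ring-bearing groups of compound 1 and compound 2 can therefore no longer be read as the only groups that go with a high number, and among the four compounds only the (carboxymethyl)(methyl)amino group goes with a low one. Against the two anilides, only floors can be read, an at least 1.7-fold lower number from compound 2 to compound 4 (0.23 log units; that floor lies within the scatter) and an at least 1.7-fold lower number from compound 1 to compound 4 (0.23 log units; that floor lies within the scatter), and compound 1 and compound 2 each stand at a limit rather than a number: the limit of > 50000 nM in this assay, at which 2 of the 4 values shown sit.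

Compound 4 differs from compound 3 in several features at once, including the carboxylic acid, the methyl on the amide-type nitrogen and the branched chain with its hydroxymethyl, so the compounds shown do not say which of these carries the step. A methyl ester in place of the carboxylic acid, a carboxymethylamino group without the methyl, or a carboxylic acid in place of the hydroxymethyl of compound 4 would separate them.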